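Hydroxy for chloro on the hydroxamic acid pair: notes

The source may report more compounds than this note shows. Statements on the series, on what has been measured and on what is new or still open speak of the compounds shown alone.

Four members of the series share one core. Compound 1 `O=C(O)c1cn(Cc2ccc(Cl)cc2)c2ccccc2c1=O` carries a carboxylic acid and a 4-chlorophenyl group; in a functional assay, tested at 50 uM (a higher number here means a stronger effect of the compound at the concentration tested, a lower number a weaker effect), compound 1 is recorded as "not determined" (no result reported). Compound 2 `O=C(O)c1cn(Cc2ccc(O)cc2)c2ccccc2c1=O` is the hydroxy counterpart of compound 1, and in this assay compound 2 gives 30.4%. Compound 3 `O=C(NO)c1cn(Cc2ccc(Cl)cc2)c2ccccc2c1=O` replaces the carboxylic acid of compound 1 by a hydroxamic acid; in this assay compound 3 is recorded as "not determined" (no result reported), and compound 1 likewise has no number, so compound 3 stands nowhere on the numbers known, and the one other entry without a number gives no foothold either.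

Compound 4 `O=C(NO)c1cn(Cc2ccc(O)cc2)c2ccccc2c1=O` is the next member. Relative to compound 3 the change is hydroxy in place of chloro on an aromatic carbon, the same exchange that separates compound 2 from compound 1. Going by the values given here, no step between two measured compounds exists, and no number for compound 3 is known, so no size or direction of a step in this assay can be set against anything seen; the only anchor is compound 2 with 30.4%, and a step of comparable or somewhat larger size is expected rather than one beyond all measure. For compound 4 in this assay the expected value is 45%, with a range from 10% to 85%.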

Compound 4, a percentage reported as activity, at one concentration (the size of the read-out at that concentration, not a potency): 51.1%
For compound 4 the middle estimate is 6.1 percentage points below the measured one; the measured number falls inside the stated range.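

With the 4-hydroxyphenyl group held constant, the series now has its first readable step, and it lies at the carbonyl end rather than on the aromatic ring: in this assay the exchange of the carboxylic acid for the hydroxamic acid gives a number 20.7 percentage points higher from compound 2 to compound 4 (beyond the scatter) and so separates this pair. Going by these compounds alone, the size of the chloro to hydroxy exchange stays unknown, since the steps that would show it cannot be read with no number for compound 1 or compound 3, and the gain therefore rests on the single pair with the 4-hydroxyphenyl group. No data at hand give a cause for the step.

Open, on these data alone, is whether the hydroxamic acid would give a similar gain with the 4-chlorophenyl group, and whether a primary amide or a methyl ester on the same carbonyl carbon would match compound 4 or compound 2. Also open, as far as these compounds go, is how an amino or methoxy group in place of the hydroxy on the aromatic carbon would read, and, with one tested concentration, how these read-outs relate to potency.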